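A few compounds are considered here, and "the series" means these few. Any claim that something is new, unique, unknown or untested is made for them only; others in the source may bear on it.

The compounds measured so far:

Compound 1 `C=C1[C@H](O)[C@@H](OC(=O)C(C)(C)C)[C@@H](O)C(C)(C)/C=C/[C@H](C)[C@H](OC(=O)c2ccccc2)[C@@]2(O)C[C@@](C)(O)[C@H](OC(C)=O)[C@@H]2[C@H]1OCC(C)C` gives 64200 nM in a functional assay on NCI/ADR-RES cells (Homo sapiens) for positive allosteric modulation, read by MTT assay, with a stated time of 48 h, tested at 10 uM; a higher number here means a weaker inhibitor, a lower number a stronger inhibitor.
Compound 2 `C=C1[C@H](OC(C)=O)[C@@H](OC(C)=O)[C@@H](OC(C)=O)C(C)(C)/C=C/[C@H](C)[C@H](OC(=O)c2ccccc2)[C@@]2(O)C[C@@](C)(OC(C)=O)[C@H](OC(C)=O)[C@@H]2[C@H]1OCC(C)C` gives 4810 nM in this assay.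
Compound 3 `C=C1[C@H](OC(C)=O)[C@@H](OC(C)=O)[C@@H](OC(C)=O)C(C)(C)/C=C/[C@H](C)[C@H](OC(=O)c2ccccc2)[C@@]2(O)C[C@@](C)(OC(=O)c3ccncc3)[C@H](OC(C)=O)[C@@H]2[C@H]1OCC(C)C` gives 650 nM in this assay.

Compound 3 stands with the lowest of the three numbers in this assay, compound 2 the nearest to it and compound 1 the furthest. For the measured compounds named here, the one step measured between compounds that differ in a single place, a 7.4-fold lower number from compound 2 to compound 3 (0.87 log units; beyond the scatter), took the value down when an aromatic ring replaced the methyl on that carbonyl carbon.

Compound 4 `C=C1[C@H](OC(C)=O)[C@@H](OC(C)=O)[C@@H](OC(C)=O)C(C)(C)/C=C/[C@H](C)[C@H](OC(=O)c2ccccc2)[C@@]2(O)C[C@@](C)(OC(=O)c3cccc(C)c3)[C@H](OC(C)=O)[C@@H]2[C@H]1OCC(C)C` differs from compound 3 in one place: 3-methylphenyl in place of pyridin-4-yl on a carbonyl carbon. Going by the values given here, no measured pair shows what exchanging one six-membered aromatic ring for another does at this position, so the only step that bears on it, a 7.4-fold lower number from compound 2 to compound 3 (0.87 log units; beyond the scatter), speaks indirectly. It shows that an aromatic ring on that carbonyl carbon lowers the number relative to the methyl of compound 2; compound 4 keeps an aromatic ring there, so the number is expected to remain nearer compound 3 than compound 2, with no firm reason to expect a shift beyond the scatter in either direction. The expected step is a 1.4-fold higher number from compound 3 to compound 4 (0.14 log units; within the scatter). Compound 4 is therefore estimated at 900 nM, within a range from 250 nM to 3500 nM.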

Compound 4, half-maximal inhibitory concentration: 1510 nM
For compound 4 the middle estimate is 1.7-fold (0.22 log units) below the measured one; low and high end bracket the measured number.
By their numbers in this assay, from the lowest: compound 3; then compound 4; then compound 2; then compound 1.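

Compound 4 shows that the identity of the aromatic ring on this carbonyl carbon matters in this assay: exchanging pyridin-4-yl for 3-methylphenyl gives a 2.3-fold higher number from compound 3 to compound 4 (0.37 log units; beyond the scatter), a step beyond the scatter, so the two rings cannot be treated as interchangeable. The gain over the methyl of compound 2 nevertheless survives this exchange, with 3-methylphenyl in place of methyl giving a 3.2-fold lower number from compound 2 to compound 4 (0.50 log units; beyond the scatter), so both aromatic rings shown at this position give a lower number than methyl, though the carbon-only ring gives the smaller drop. The exchange also removes the ring nitrogen and adds a methyl in a single move, and these two compounds cannot separate what each of those changes contributes.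

The compounds shown leave open how an unsubstituted phenyl or a pyridin-3-yl on this carbonyl carbon would read, and either would help to divide the step between the ring nitrogen and the methyl. Nothing available here explains why the number moves with the ring at this position.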